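The compounds below may be only part of what the source reports. "The series", "measured", "known", "first", "only" and "open" are said of these compounds alone.

Measured so far:
Compound 1, `CCOC(=O)c1cn(Cc2ccccc2F)c2cc(-c3ccc(OC)cc3)c(CN(C)Cc3ccccc3)n2c1=O`: 400 nM
Compound 2, `CCC(CC)OC(=O)c1cn(Cc2ccccc2F)c2cc(-c3ccc(OC)cc3)c(CN(C)Cc3ccccc3)n2c1=O`: 62 nM

Both were tested in an assay on HEK293 cells for binding affinity to Gonadotropin-releasing hormone receptor (Homo sapiens), read by radioligand binding; a higher number here means a weaker inhibitor, a lower number a stronger inhibitor. Within the data shown here, compound 2 stands at the lower end of these two numbers, and the only neighbour is compound 1, whose number is higher by a 6.5-fold lower number from compound 1 to compound 2 (0.81 log units; beyond the scatter). That one step concerns the ester end of the shared core, where pentan-3-yl replaced ethyl.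

Compound 3, `CCC(CC)OC(=O)c1cn(Cc2ccccc2F)c2cc(-c3ccc(NC(C)=O)cc3)c(CN(C)Cc3ccccc3)n2c1=O`, has not yet been measured. It keeps the pentan-3-yl ester of compound 2 and differs at the other side of the core: acetamido in place of methoxy on an aromatic carbon. Among the measured compounds shown here, the only measured step, the ester change, touches a different part of the molecule, so nothing measured here speaks directly to swapping methoxy for acetamido. With no guide, the expectation is a step of moderate size in either direction, and the estimate leans slightly towards a higher number: the expected step from compound 2 is a 1.6-fold higher number from compound 2 to compound 3 (0.21 log units; within the scatter). In this assay compound 3 is therefore estimated at 100 nM, with a likely range from 25 nM to 400 nM.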

Compound 3, inhibition constant: 4 nM
Estimate against measurement, compound 3: 25-fold (1.40 log units) above; the whole stated range lies above it.
By their numbers in this assay, from the lowest: compound 3; then compound 2; then compound 1.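

The aromatic carbon para to a large group proves to be a sensitive place in this assay, and acetamido in place of methoxy there gives a 16-fold lower number from compound 2 to compound 3 (1.19 log units; beyond the scatter) with the pentan-3-yl ester held constant. The change from 4-methoxyphenyl to 4-acetamidophenyl brings in a nitrogen, a hydrogen-bond donor and a double bond outside the aromatic rings, and this single pair of compounds cannot show which of these differences matters. Nothing available here explains the size of this step.

The compounds shown leave open how much of the acetamido group is needed, which a plain amine, a longer propionamido chain or a methyl carbamate on the same carbon would help to show. They also leave open whether 4-acetamidophenyl would give a similar step alongside the ethyl ester of compound 1, since here the change is seen only alongside the pentan-3-yl ester.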